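Methoxy to hydroxy: from compound 3 toward compound 4

A few compounds are considered here, and "the series" means these few. Any claim that something is new, unique, unknown or untested is made for them only; others in the source may bear on it.

Three compounds of the series have numbers in a functional assay on KM12 cells (Homo sapiens) for cytotoxicity, read by sulforhodamine B assay, with a stated time of 48 h, tested at 10 uM; on this read-out higher numbers stand for a weaker effect at the one concentration tested and lower numbers for a stronger effect. Compound 1 `COc1cc(C)cc(-c2nn(CC#N)cc2-c2ccc(-c3cccc(C(C)=O)c3)nc2)c1` gives -25%, compound 2 `Cc1cc(O)cc(-c2nn(CC#N)cc2-c2ccnc(-c3ccc(Oc4ccccc4)cc3)c2)c1` gives -100%, and compound 3 `COc1cc(C)cc(-c2nn(CC#N)cc2-c2ccnc(-c3ccc(N(C)C)cc3)c2)c1` gives -70%. Compound 3 stands second highest of the three; its nearest neighbour is compound 2, lower by a margin beyond the scatter, and its furthest is compound 1, higher, also beyond the scatter. Compound 4 `Cc1cc(O)cc(-c2nn(CC#N)cc2-c2ccnc(-c3ccc(N(C)C)cc3)c2)c1` awaits measurement and differs from compound 3 in one place: hydrogen in place of methyl on an oxygen on an aromatic ring. Cut one bond further out, methoxy becomes hydroxy. Going by the values given here, no measured pair isolates this change; compound 2 has the hydroxy but differs from compound 3 elsewhere too. The step from compound 3 to compound 4 in this assay is expected to be modest, toward a stronger effect, a number 10 percentage points lower from compound 3 to compound 4 (within the scatter). Compound 4 is estimated at -80%, between -100% and -50%.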

Compound 4, a percentage reported as activity, at one concentration (the size of the read-out at that concentration, not a potency): -97%
Estimate against measurement, compound 4: 17 percentage points above; measured number inside the range.
By their numbers in this assay, from the lowest: compounds 2 and 4 (each within the scatter of the next); then compound 3; then compound 1.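

In this assay, the methoxy to hydroxy change on the 3-methoxy-5-methylphenyl group can now be read on its own: a number 27 percentage points lower from compound 3 to compound 4 (beyond the scatter), so this oxygen substituent matters in this series. With the hydroxy in place, dimethylamino in place of phenoxy on an aromatic carbon gives a number 3 percentage points higher from compound 2 to compound 4 (within the scatter), so this exchange is not resolved on this read-out. Nothing at hand explains either step.

As far as these compounds go, whether an amine or a carboxylic acid in place of the hydroxy would keep the effect remains open. From the compounds shown here alone, the size of the methoxy to hydroxy step with phenoxy in place of dimethylamino also remains open.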